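The compounds below may be only part of what the source reports. "The series", "measured", "known", "first", "only" and "open" are said of these compounds alone.

Three compounds built on an amide with an isopropyl group and a benzyl arm that carries a six-carbon oxygen-linked chain were examined for cytotoxicity. Compound 1 `COc1cc(OC)cc(-c2ccc(C(=O)N(Cc3cccc(OCCCCCC(=O)O)c3)C(C)C)cc2)c1` carries a carboxylic acid at the end of that chain. In an ADME assay on Raji cells (Homo sapiens) for cytotoxicity, read by CellTiter-Glo and resazurin assay, with a stated time of 72 h (a lower number here means that less compound is needed, a higher number that more compound is needed for the effect), compound 1 gives > 26000 nM, which is a limit of the assay rather than a number. Compound 2 `CC(C)N(Cc1cccc(OCCCCCC(=O)O)c1)C(=O)c1ccc(-c2cc3ccccc3n2S(=O)(=O)c2ccccc2)cc1` carries the same acid on a different core; the difference between the two cores is not broken down here. In this assay compound 2 gives > 26000 nM, again only a limit. Compound 3 `CCOC(=O)CCCCCOc1cccc(CN(C(=O)c2ccc(-c3cc(OC)cc(OC)c3)cc2)C(C)C)c1` is the ethyl ester of compound 1 (ethyl in place of hydrogen on an oxygen next to a carbonyl group). In this assay compound 3 gives > 26000 nM, also a limit, so the step that the two limits leave unreadable from compound 1 to compound 3 cannot be read. All three values sit together (the limit of > 26000 nM in this assay, at which 3 of the 3 values shown sit).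

Compound 4 `CCOC(=O)CCCCCOc1cccc(CN(C(=O)c2ccc(-c3cc4ccccc4n3S(=O)(=O)c3ccccc3)cc2)C(C)C)c1` is the ethyl ester of compound 2, the same change ethyl in place of hydrogen on an oxygen next to a carbonyl group applied to the other core. Because compound 1, compound 2 and compound 3 all sit at the limit (the limit of > 26000 nM in this assay, at which 3 of the 3 values shown sit), compound 4 is expected to show a step that the limit leaves unreadable from compound 2 to compound 4 and an estimated value near 30000 nM, most likely reported again only as a limit.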

Compound 4, half-maximal effective concentration: > 26000 nM
Compound 4 gave a limit, no number; the forecaster's own chance of this, stated with the estimate: 85%; the middle value lies beyond the limit too.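

In this assay compound 4 gives > 26000 nM, again a limit of the assay and not a number. Compound 2 also stands only at a limit, so the step between compound 2 and compound 4 cannot be read. The compounds shown leave open how far the acids and their ethyl esters differ in this assay, if they differ at all.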